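A few compounds are considered here, and "the series" means these few. Any claim that something is new, unique, unknown or untested is made for them only; others in the source may bear on it.

Measured compounds and their values in an ADME assay on microsomes from liver (Homo sapiens), read by LC-MS, using NADPH, with a stated time of 30 min, tested at 1 uM; on this read-out higher numbers stand for a more stable compound and lower numbers for a less stable compound:
compound 1, `C[C@H](Nc1nc(N)nc(N)c1C#N)c1cc2ccc(F)cn2c(=O)c1-c1ccccc1`: 87%
compound 2, `Cc1nc(N)nc(N[C@@H](C)c2cc3ccc(F)cn3c(=O)c2-c2ccccc2)c1C#N`: 83%
compound 3, `Cc1cc(F)cc(-c2c([C@H](C)Nc3nc(N)nc(N)c3C#N)cc3ccc(F)cn3c2=O)c1`: 80%

Compound 1 gives the largest of the three numbers, yet the steps from compound 1 to compound 2 and to compound 3 both stay inside the usual scatter, so the three compounds cannot really be told apart on this read-out. Compound 4, `C[C@H](Nc1nc(N)nc(N)c1C#N)c1c(-c2ccccc2)c(=O)n2cc(F)ccc2c1-c1ccc(C(N)=O)cc1`, differs from compound 1 in one place: 4-carbamoylphenyl in place of hydrogen on an aromatic carbon. Two measured steps offer some guidance. The step of a number 4 percentage points lower from compound 1 to compound 2 (within the scatter) swapped a small group at another part of the core, and the step of a number 7 percentage points lower from compound 1 to compound 3 (within the scatter) changed the phenyl group; neither moved the number beyond the scatter. Neither step, however, adds a group of this size, so the guidance is loose. The expectation for compound 4 is a step of a number 12 percentage points lower from compound 1 to compound 4 (beyond the scatter) downward, small enough that it may still lie within the scatter. Compound 4 is therefore estimated to give 75% in this assay, with a plausible range from 55% to 92%.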

Compound 4, percent of the compound remaining: 105%
The estimate for compound 4 lay 30 percentage points below the measured number; measured number outside the range, above it.
By their numbers in this assay, from the lowest: compounds 3, 2 and 1 (each within the scatter of the next); then compound 4.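

In this assay this place on the core, two atoms from the ring nitrogen, takes a large group without any loss of stability: putting 4-carbamoylphenyl in place of hydrogen gives a number 18 percentage points higher from compound 1 to compound 4 (beyond the scatter) and is the only step among the compounds shown that lies beyond the scatter. The earlier compounds shown here changed only other parts of the molecule, so they said nothing about this place. No measurement shown here explains why the number rose.

With a single group at this place, the ring and the carboxamide on it cannot be separated, so a plain phenyl group would show what the ring does alone. A carboxylic acid or an aminomethyl group in place of the carboxamide would show whether this gain depends on that particular end group.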